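Crown ether esters: changing the acyl group on compound 2

This account rests on a few compounds, and the source may have more. Where it says the series, first, only, none or still open, it means among the compounds named here.

Compound 2 `CC(C)=CC1C(C(=O)OCC2COCCOCCOCCOCCOCCO2)C1(C)C` gives the lowest of the two numbers in a functional assay on SW1573 cells (Homo sapiens) for inhibition, read by sulforhodamine B assay, with a stated time of 48 h (a lower number here means a stronger inhibitor of growth, a higher number a weaker inhibitor of growth), with 54000 nM; its nearest neighbour is compound 1 `O=C(CCCCCc1ccccc1)OCC1COCCOCCOCCOCCOCCO1`, which in this assay gives 78000 nM, a gap within the scatter. Compound 3 `O=C(/C=C/c1ccccc1)OCC1COCCOCCOCCOCCOCCO1` differs from compound 2 by 2-phenylethenyl in place of 2,2-dimethyl-3-(2-methylprop-1-en-1-yl)cyclopropyl on a carbonyl carbon. Going by the values given here, the only comparable step, a 1.4-fold lower number from compound 1 to compound 2 (0.16 log units; within the scatter), also exchanged the whole acyl group and stayed within the scatter, so no step beyond the scatter is expected here, in either direction. Compound 3 is estimated at 60000 nM in this assay, between 20000 nM and 180000 nM, which means an expected step of a 1.1-fold higher number from compound 2 to compound 3 (0.05 log units; within the scatter).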

Compound 3, concentration for 50% growth inhibition: 48000 nM
For compound 3 the middle estimate is 1.3-fold (0.10 log units) above the measured one; low and high end bracket the measured number.
By their numbers in this assay, from the lowest: compounds 3, 2 and 1 (each within the scatter of the next).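

On a carbonyl carbon, 2-phenylethenyl in place of 2,2-dimethyl-3-(2-methylprop-1-en-1-yl)cyclopropyl gives a 1.1-fold lower number from compound 2 to compound 3 (0.05 log units; within the scatter) in this assay, and in place of 5-phenylpentyl gives a 1.6-fold lower number from compound 1 to compound 3 (0.21 log units; within the scatter). All three acyl groups now read alike within the scatter, including a pair with an aromatic ring and one with a three-membered ring, so this position has not yet shown a step beyond the scatter. Going by these compounds, whether an acyl group bearing an amine or a carboxylic acid, or a shorter chain such as acetyl, would produce such a step stays open. No evidence bearing on this result is available.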